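Swapping isopentyloxy for octyl on compound 2

This account rests on a few compounds, and the source may have more. Where it says the series, first, only, none or still open, it means among the compounds named here.

Measured so far in a functional assay on brain (Rattus norvegicus, strain Wistar) for inhibition; on this read-out lower numbers stand for stronger inhibition and higher numbers for weaker inhibition
- compound 1 (`CCCCCCCCc1ccc(-c2c(C)[nH]c(=O)n2C)cc1`) gives 19400 nM
- compound 2 (`Cc1[nH]c(=O)n(C2CCCCC2)c1-c1ccc(OCCC(C)C)cc1`) gives 7200 nM

Of these two numbers, compound 2 has the lower (7200 nM), and its gap to compound 1 lies beyond the scatter. Compound 3 (`CCCCCCCCc1ccc(-c2c(C)[nH]c(=O)n2C2CCCCC2)cc1`) differs from compound 2 by octyl in place of isopentyloxy on an aromatic carbon. Octyl also occurs in compound 1 (19400 nM), but that compound differs from compound 2 in a second place too. Among the compounds with values here, no measured pair isolates this change, so in this assay only a small shift, not beyond the scatter, is expected (a 1.1-fold lower number from compound 2 to compound 3 (0.04 log units; within the scatter)). For compound 3 the estimated value is 6500 nM (range 2500 nM to 18000 nM).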

Compound 3, half-maximal inhibitory concentration: 10300 nM
Compound 3: the middle estimate sits 1.6-fold (0.20 log units) below what was measured, and the stated range covers the measured number.
By their numbers in this assay, from the lowest: compounds 2, 3 and 1 (each within the scatter of the next, the first and the last beyond it).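

In this assay, octyl in place of isopentyloxy on the aromatic carbon gives a 1.4-fold higher number from compound 2 to compound 3 (0.16 log units; within the scatter) with cyclohexyl held constant, so this position tolerates the ether chain and the all-carbon chain alike. With octyl held constant, cyclohexyl in place of methyl on the aromatic nitrogen gives a 1.9-fold lower number from compound 1 to compound 3 (0.27 log units; within the scatter) and likewise stays within the scatter. No supporting data bear on either step.

Still open, going by these compounds, is whether a shorter chain, or a chain ending in an amine or a carboxylic acid, would shift the number beyond the scatter at this position. Also open, on these data alone, is how a benzyl group on the nitrogen would compare with cyclohexyl and methyl.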